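The compounds below may be only part of what the source reports. "The series", "measured", "known", "first", "only" and "open" are said of these compounds alone.

Among the compounds with values here, in a functional assay on HCT-116 cells (Homo sapiens) for antiproliferative activity, read by MTT assay, with a stated time of 24 h (on this read-out higher numbers stand for weaker inhibition and lower numbers for stronger inhibition), compound 1 `COc1ccc(-c2noc(-c3ccc(F)cc3)n2)cc1OC1CCCC1` gives 210000 nM, the only actual number so far. Compound 2 `COc1ccc(-c2noc(-c3cccnc3)n2)cc1OC1CCCC1` gives > 1000000 nM, which is a limit of the assay and not a number. Within the data shown here, the one measured step is an at least 4.7-fold higher number from compound 1 to compound 2 (0.67 log units; beyond the scatter), and its size stays open on one side, given (the limit of > 1000000 nM in this assay, at which 1 of the 2 values shown sits).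

Compound 3 `COc1ccc(-c2noc(-c3ccc(F)cc3)n2)cc1O` keeps the 4-fluorophenyl of compound 1 and differs elsewhere: hydrogen in place of cyclopentyl on an oxygen on an aromatic ring, that is, cyclopentyloxy to hydroxy. Among the measured compounds shown here, no measured step touches this oxygen. The step to compound 2, an at least 4.7-fold higher number from compound 1 to compound 2 (0.67 log units; beyond the scatter), lies on an aromatic carbon instead, so it bears on the new change only loosely, showing that a single exchange on compound 1 can move the number beyond the scatter. A modest rise in the number is therefore expected in this assay, although a result within the scatter would not be surprising. The estimated change is a 1.7-fold higher number from compound 1 to compound 3 (0.22 log units; within the scatter). For compound 3 the expected value is 350000 nM, with an estimated range of 100000 nM to 1000000 nM.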

Compound 3, half-maximal inhibitory concentration: > 1000000 nM
Compound 3: only a limit was reported (the forecaster's own chance of this, stated with the estimate: 25%); middle value at least 2.8-fold (0.45 log units) from the limit.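

The oxygen on the aromatic ring now has a measured step of its own: in this assay, hydrogen in place of cyclopentyl gives an at least 4.7-fold higher number from compound 1 to compound 3 (0.67 log units; beyond the scatter), a change beyond the scatter towards weaker inhibition. Compound 3 gives > 1000000 nM, which is a limit of the assay and not a number. This oxygen thus joins the aromatic carbon as a second place where a single exchange on compound 1 raises the number beyond the scatter, but the size of the new step stays open on one side, and compound 1 remains the only compound in the series with an actual number: the limit of > 1000000 nM in this assay, at which 2 of the 3 values shown sit.

The compounds shown leave open whether the cyclopentyl ring itself is needed or whether another group on this oxygen would serve as well, such as a methyl, a longer chain like n-butyl, or a cyclohexyl. They also leave open whether a chain ending in an amine or a carboxylic acid at this oxygen would keep the number near that of compound 1 or carry it to the limit of the assay.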